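Methoxy on the terminal phenyl: compound 3 to compound 4

The compounds below may be only part of what the source reports. "The series", "measured", "known", "first", "only" and "open" are said of these compounds alone.

In a functional assay on MCF7 cells (Homo sapiens) for cytotoxicity, read by MTT assay, with a stated time of 24 h (a higher number here means a weaker inhibitor, a lower number a stronger inhibitor), the three measured compounds give:
Compound 1 `COc1ccccc1N1CCN(CC(=O)N2CCN(c3nnc(-c4ccccc4)c(-c4ccccc4)n3)CC2)CC1`: 167000 nM
Compound 2 `O=C(CN1CCN(c2cccc(Cl)c2)CC1)N1CCN(c2nnc(-c3ccccc3)c(-c3ccccc3)n2)CC1`: 56300 nM
Compound 3 `Cc1ccc(-c2nnc(N3CCN(C(=O)CN4CCN(c5ccccc5)CC4)CC3)nc2-c2ccc(C)cc2)cc1`: 914000 nM

Compound 3 stands highest of the three, beyond the scatter from both compound 1 and compound 2. Compound 4 `COc1ccc(N2CCN(CC(=O)N3CCN(c4nnc(-c5ccc(C)cc5)c(-c5ccc(C)cc5)n4)CC3)CC2)cc1` differs from compound 3 by methoxy in place of hydrogen on an aromatic carbon. Going by the values given here, the only single-point step measured, a 3.0-fold lower number from compound 1 to compound 2 (0.47 log units; beyond the scatter), exchanges one substituted phenyl for another and so bears only loosely on adding a methoxy to an unsubstituted phenyl; it shows that changes on this ring move this assay modestly. Compound 1 carries a methoxyphenyl and sits below compound 3, but two changes separate them. Compound 4 is therefore expected to show a small step, a 1.7-fold lower number from compound 3 to compound 4 (0.22 log units; within the scatter), within or near the scatter, with an estimate of 550000 nM and a range from 150000 nM to 2000000 nM.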

Compound 4, half-maximal inhibitory concentration: 53000 nM
Compound 4: the middle estimate sits 10-fold (1.02 log units) above what was measured; the whole stated range lies above it.
By their numbers in this assay, from the lowest: compounds 4 and 2 (each within the scatter of the next); then compound 1; then compound 3.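

In this assay, going by these compounds alone, phenyl to 4-methoxyphenyl gives a 17-fold lower number from compound 3 to compound 4 (1.24 log units; beyond the scatter), a large step, whereas the one earlier change on this ring, a 3.0-fold lower number from compound 1 to compound 2 (0.47 log units; beyond the scatter), was modest. Within the data shown here, this shows that a single methoxy on an aromatic carbon, para to a large group, can move the number far more than the earlier compounds indicated. Nothing available bears on the cause of this step.

From the compounds shown here alone, whether the methoxy gives a step of this size on the core of compound 1 remains open. So does what an amine, a carboxylic acid or a longer chain such as ethoxy would do at this place.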